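Amide variants on the shared core: cycloheptyl to cyclooctyl

The source may report more compounds than this note shows. Statements on the series, on what has been measured and on what is new or still open speak of the compounds shown alone.

Measured compounds:
compound 1, `CCCCNC(=O)[C@H]1OC(n2cnc3c(N)ncnc32)[C@H](O)[C@@H]1O`, 17 nM
compound 2, `CCCCCCNC(=O)[C@H]1OC(n2cnc3c(N)ncnc32)[C@H](O)[C@@H]1O`, 19 nM
compound 3, `Nc1ncnc2c1ncn2C1O[C@H](C(=O)NC2CCCCCC2)[C@@H](O)[C@H]1O`, 22 nM

The three measured compounds share one core and differ only in the group on the amide-type nitrogen. In an assay on cell membranes for binding affinity to 2-oxoglutarate receptor 1 (Rattus norvegicus), read by radioligand binding (on this read-out higher numbers stand for weaker inhibition and lower numbers for stronger inhibition), compound 1 gives 17 nM, compound 2 gives 19 nM and compound 3 gives 22 nM. Compound 3 sits within the scatter of both others: a 1.3-fold higher number from compound 1 to compound 3 (0.11 log units; within the scatter) and a 1.2-fold higher number from compound 2 to compound 3 (0.06 log units; within the scatter). The chain extension a 1.1-fold higher number from compound 1 to compound 2 (0.05 log units; within the scatter) is likewise within the scatter.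

Compound 4, `Nc1ncnc2c1ncn2C1O[C@H](C(=O)NC2CCCCCCC2)[C@@H](O)[C@H]1O`, is the next member: cyclooctyl in place of cycloheptyl on an amide-type nitrogen. Going by the values given here, the steps that bear on it are those in which the group on the amide-type nitrogen grows, from butyl to hexyl, from butyl to cycloheptyl and from hexyl to cycloheptyl, and all three lay within the scatter. Going one ring carbon further, no step beyond the scatter is expected in this assay. Compound 4 is estimated at 25 nM, with a range from 10 nM to 60 nM, which means an expected step of a 1.1-fold higher number from compound 3 to compound 4 (0.06 log units; within the scatter).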

Compound 4, inhibition constant: 23 nM
Estimate against measurement, compound 4: 1.1-fold (0.04 log units) above, and the stated range covers the measured number.
By their numbers in this assay, from the lowest: compounds 1, 2, 3 and 4 (each within the scatter of the next).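

In this assay, adding one more carbon to the ring on the amide-type nitrogen produces no readable change (a 1.0-fold higher number from compound 3 to compound 4 (0.02 log units; within the scatter)). Cyclooctyl also stays level with the open chains, both against hexyl (a 1.2-fold higher number from compound 2 to compound 4 (0.08 log units; within the scatter)) and against butyl (a 1.4-fold higher number from compound 1 to compound 4 (0.13 log units; within the scatter)), so an eight-membered carbon ring joins butyl, hexyl and cycloheptyl with every comparison at this position still within the scatter. No available measurement accounts for this flat response.

The compounds shown leave open whether this flatness extends to a smaller ring such as cyclopropyl, an aromatic ring such as phenyl, or a longer chain such as decyl. They also leave open what an amine or a carboxylic acid on the group would do, and what would follow if methyl replaced the amide hydrogen.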